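The compounds below may be only part of what the source reports. "The series", "measured", "known", "first", "only" and "open" are said of these compounds alone.

In a functional assay on HepG2 cells (Homo sapiens) for antiproliferative activity, read by CCK-8 assay, with a stated time of 72 h (a higher number here means a weaker inhibitor, a lower number a stronger inhibitor), three compounds have been measured so far:

compound 1 `COc1ccc(C(=O)Nc2cccc(-c3oc4cc(-c5ccc(F)cc5)ccc4c(=O)c3O)c2)cc1` gives 8420 nM
compound 2 `Cc1cccc(C(=O)Nc2cccc(-c3oc4cc(-c5ccc(F)cc5)ccc4c(=O)c3O)c2)c1` gives 13500 nM
compound 3 `Cc1cc(C(=O)Nc2cccc(-c3oc4cc(-c5ccc(F)cc5)ccc4c(=O)c3O)c2)ccc1F` gives 9540 nM

All three share the same core and differ only in the aryl group carried on the carbonyl carbon of the amide. Compound 3 has the second highest of the three numbers, yet neither gap sets it apart: a 1.1-fold higher number from compound 1 to compound 3 (0.05 log units; within the scatter) and a 1.4-fold lower number from compound 2 to compound 3 (0.15 log units; within the scatter) both fall within the scatter, so the three compounds cannot be ranked against one another.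

Compound 4 `COc1cc(OC)cc(C(=O)Nc2cccc(-c3oc4cc(-c5ccc(F)cc5)ccc4c(=O)c3O)c2)c1` is the next variation on the same theme: 3,5-dimethoxyphenyl in place of 4-fluoro-3-methylphenyl on a carbonyl carbon. Among the measured compounds shown here, two measured steps bear on this change. Exchanging the 4-methoxyphenyl of compound 1 for the 4-fluoro-3-methylphenyl of compound 3 gave a 1.1-fold higher number from compound 1 to compound 3 (0.05 log units; within the scatter), and exchanging it for the 3-methylphenyl of compound 2 gave a 1.6-fold higher number from compound 1 to compound 2 (0.21 log units; within the scatter), both within the scatter. A ring carrying methoxy groups has thus already been tried in this position without a visible effect, and a second methoxy is the only new element. No step beyond the scatter is therefore expected in this assay in either direction, so a 1.0-fold lower number from compound 3 to compound 4 (0.00 log units; within the scatter) is the expected outcome. Compound 4 is estimated at 9500 nM, with a likely range from 4500 nM to 20000 nM.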

Compound 4, half-maximal inhibitory concentration: 23500 nM
Compound 4: middle estimate off by 2.5-fold (0.39 log units), on the low side, outside the stated range (above it).
By their numbers in this assay, from the lowest: compounds 1, 3, 2 and 4 (each within the scatter of the next, the first and the last beyond it).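

In this assay, among the compounds shown here, the aryl group on the carbonyl carbon of the amide can shift the number after all: the 3,5-dimethoxyphenyl group gives a 2.5-fold higher number from compound 3 to compound 4 (0.39 log units; beyond the scatter) and a 2.8-fold higher number from compound 1 to compound 4 (0.45 log units; beyond the scatter), the only steps in this set that go beyond the scatter, both modest. The effect is limited, however, as a 1.7-fold higher number from compound 2 to compound 4 (0.24 log units; within the scatter) stays within the scatter, so compound 4 cannot be separated from compound 2, and the step from compound 1 shows that a ring with methoxy groups is not interchangeable with every other ring carrying them. The step from compound 1 changes both the number of methoxy groups and where they sit, and nothing available here explains the higher number or tells those two changes apart.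

Still open, from the compounds shown here alone, is whether a 3-methoxyphenyl group, with a single methoxy, would stand with compound 1 or with compound 4, which would help separate those two changes. Also open, going by these compounds, is how this position responds to quite different groups, such as a ring carrying an amine or a carboxylic acid, or a longer chain in place of the aryl ring.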